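Working notes: two measured compounds, one awaiting measurement

A few compounds are considered here, and "the series" means these few. Any claim that something is new, unique, unknown or untested is made for them only; others in the source may bear on it.

Measured so far:
compound 1, `OC[C@@H]1CCC[C@@H]1Cn1cnc2c(Cl)ncnc21`, 52500 nM
compound 2, `O=c1[nH]c(=O)n([C@H]2C[C@H](O)[C@@H](CO)O2)cc1CO`, 9180 nM

In an ADME assay on L1210/0 cells (Mus musculus) for cytotoxicity, with a stated time of 48 h (a higher number here means a weaker inhibitor, a lower number a stronger inhibitor), compound 1 gives 52500 nM, while compound 2 gives 9180 nM. Compound 2 thus holds the lower of the two numbers, and its gap to compound 1 lies beyond the usual scatter. Within the data shown here, the two share no single-point difference, so no step between measured compounds is available to guide what follows.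

Compound 3, `CCCC#Cc1cn([C@H]2C[C@H](O)[C@@H](CO)O2)c(=O)[nH]c1=O`, is still to be measured in this assay. Relative to compound 2 it carries pent-1-yn-1-yl in place of hydroxymethyl on an aromatic carbon. Among the measured compounds shown here, nothing among the measured pairs bears directly on this exchange, so the expectation rests on compound 2 alone and is held loosely. A modest weakening is expected, with a 2.2-fold higher number from compound 2 to compound 3 (0.34 log units; beyond the scatter) judged not far beyond the scatter. Compound 3 is therefore estimated at 20000 nM, within a range from 4000 nM to 100000 nM.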

Compound 3, half-maximal inhibitory concentration: > 200000 nM
Compound 3 was reported as a limit; the forecaster's own chance of this, stated with the estimate: 10%; at least 10-fold (1.00 log units) between middle value and limit.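

In this assay compound 3 gives > 200000 nM, which is a limit of the assay and not a number: the limit of > 200000 nM in this assay, at which 1 of the 3 values shown sits.

Pent-1-yn-1-yl in place of hydroxymethyl, on the aromatic carbon two atoms from the ring nitrogen, gives an at least 21-fold higher number from compound 2 to compound 3 (1.33 log units; beyond the scatter), the first single-place comparison in the series. This position is therefore sensitive to the group it carries in this assay, and the size of the step is a minimum, resting on one pair.

This single pair cannot separate the contribution of the chain length, the triple bond and the loss of the hydroxymethyl group. The compounds shown do not tell how a saturated pentyl chain, a shorter ethynyl group or an aminomethyl group would read at this position.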